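Hydroxy in Place of Methyl on Compound 2's Aryl Ring

A few compounds are considered here, and "the series" means these few. Any claim that something is new, unique, unknown or untested is made for them only; others in the source may bear on it.

Compound 2 `C=CC[C@H]1C[C@]2([C@@H](C)Cc3ccc(OC)c(C)c3)OCOC2=CC1=O` carries a methyl beside its methoxy-bearing aryl ring. In a functional assay on M14 cells (Homo sapiens) for antiproliferative activity, with a stated time of 72 h (on this read-out higher numbers stand for weaker inhibition and lower numbers for stronger inhibition), compound 2 gives 410 nM. Compound 3 `C=CC[C@H]1C[C@]2(C(C)Cc3ccc(OC)c(OC(C)=O)c3)OCOC2=CC1=O` gives 16 nM in this assay, so of the two numbers measured, compound 2 holds the higher one and compound 3 the lower, a gap beyond the scatter. Compound 1 `C=CC[C@@H]1C[C@]2([C@@H](C)Cc3ccc(OC)c(OC)c3)OCOC2=CC1=O` reaches only a limit of this assay, > 4000 nM, and its value is no number (the limit of > 4000 nM in this assay, at which 1 of the 3 values shown sits).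

Compound 4 `C=CC[C@H]1C[C@]2([C@@H](C)Cc3ccc(OC)c(O)c3)OCOC2=CC1=O` differs from compound 2 in one place: hydroxy in place of methyl on an aromatic carbon, ortho to a methoxy group and meta to a large group. Going by the values given here, no measured pair shows this exact change, so the size of the step is open. Compound 4 is expected to give 200 nM in this assay, with a range from 30 nM to 1500 nM. That estimate means an expected step of a 2.1-fold lower number from compound 2 to compound 4 (0.31 log units; beyond the scatter), a modest move toward stronger inhibition that may not clear the usual scatter.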

Compound 4, half-maximal inhibitory concentration: 8 nM
For compound 4 the middle estimate is 25-fold (1.40 log units) above the measured one; the whole stated range lies above it.
By their numbers in this assay, from the lowest: compounds 4 and 3 (each within the scatter of the next); then compound 2. At a limit, above all of these: compound 1.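

In this assay, hydroxy in place of methyl on this aromatic carbon gives a 51-fold lower number from compound 2 to compound 4 (1.71 log units; beyond the scatter), a large step toward stronger inhibition. Going by these compounds alone, the earlier compounds offered no pair that differed at this place alone, so this is the first direct sign that the group on this carbon, ortho to a methoxy group and meta to a large group, strongly affects the antiproliferative read-out. The change adds a hydrogen-bond donor and a hydrogen-bond acceptor, but nothing shown here accounts for the size of the step.

The compounds shown leave open whether an amine or a carboxylic acid on this same carbon would match hydroxy or fall back toward methyl. This single pair also cannot tell whether the step would hold on any other core.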